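The source may hold more compounds than are shown below. What is called first, only, known or untested is meant among the compounds shown, and "the series" means these compounds.

Compound 3 `COc1ccccc1-c1ccc(Nc2nc(N[C@H]3CC[C@H](N)CC3)nc3c2ncn3C2CCCC2)cn1` gives 460 nM in an ADME assay on CCRF-CEM cells (Homo sapiens) for inhibition, read by fluorescence and resazurin assay, with a stated time of 72 h (a higher number here means a weaker inhibitor of growth, a lower number a stronger inhibitor of growth), the lowest of the three numbers in hand. Compound 2 `N[C@H]1CC[C@H](Nc2nc(Nc3ccc(-c4cccs4)nc3)c3ncn(C4CCCC4)c3n2)CC1`, at 477 nM, sits within the scatter of it, while compound 1 `N[C@H]1CC[C@H](Nc2nc(Nc3ccc(-c4ccccc4O)cc3)c3ncn(C4CCCC4)c3n2)CC1`, at 1490 nM, stands beyond the scatter above both. Compound 4 `COc1ccc(-c2ccc(Nc3nc(N[C@H]4CC[C@H](N)CC4)nc4c3ncn4C3CCCC3)cn2)cc1` differs from compound 3 by 4-methoxyphenyl in place of 2-methoxyphenyl on an aromatic carbon. Among the measured compounds shown here, the one measured step that bears on this carbon, a 1.0-fold lower number from compound 2 to compound 3 (0.02 log units; within the scatter), lay within the scatter, so exchanging the aromatic group there has so far left this assay unmoved; compounds 1 and 3 share no single-place step and offer only their two values. Compound 4 is therefore expected to show no step beyond the scatter, a 1.1-fold higher number from compound 3 to compound 4 (0.04 log units; within the scatter). Compound 4 is estimated at 500 nM, with a range from 200 nM to 1250 nM.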

Compound 4, concentration for 50% growth inhibition: 544 nM
Beside the measured number, compound 4's estimate is 1.1-fold (0.04 log units) below it, within the range that was stated.
By their numbers in this assay, from the lowest: compounds 3, 2 and 4 (each within the scatter of the next); then compound 1.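

Moving the methoxy group around the phenyl ring gave a 1.2-fold higher number from compound 3 to compound 4 (0.07 log units; within the scatter) in this assay and so did not separate 2-methoxyphenyl from 4-methoxyphenyl on this carbon next to the ring nitrogen. Exchanging thiophen-2-yl for 4-methoxyphenyl gave a 1.1-fold higher number from compound 2 to compound 4 (0.06 log units; within the scatter) and is a second aromatic exchange here that leaves the number unmoved. Nothing available explains this insensitivity. The compounds shown leave open whether a non-aromatic group on this carbon, such as an amine, a carboxylic acid or a longer chain, would move the number beyond the scatter.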